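Moving the amine around the phenyl ring

The source may report more compounds than this note shows. Statements on the series, on what has been measured and on what is new or still open speak of the compounds shown alone.

In a functional assay on A-375 cells (Homo sapiens) for inhibition, read by sulforhodamine B assay, with a stated time of 48 h (on this read-out higher numbers stand for weaker inhibition of growth and lower numbers for stronger inhibition of growth), compound 3 `COC(=O)c1sc2cc(-c3ccccc3N)cnc2c1N` gives 2500 nM, the lowest of the numbers shown. Compound 1 `COC(=O)c1sc2cc(-c3ccsc3)cnc2c1N` gives 12100 nM, and the step of a 4.8-fold lower number from compound 1 to compound 3 (0.68 log units; beyond the scatter) lies beyond the scatter. Compound 2 `COC(=O)c1sc2cc(-c3cccnc3)cnc2c1N` gives > 112000 nM; this is a limit of the assay and not a number, namely (the limit of > 112000 nM in this assay, at which 1 of the 3 values shown sits). Compound 4 `COC(=O)c1sc2cc(-c3cccc(N)c3)cnc2c1N` differs from compound 3 in one place: 3-aminophenyl in place of 2-aminophenyl on an aromatic carbon. For the measured compounds named here, none of the measured steps moves the amine within the phenyl ring; each swaps the whole ring, as in an at least 9.2-fold higher number from compound 1 to compound 2 (0.96 log units; beyond the scatter) and an at least 44-fold lower number from compound 2 to compound 3 (1.65 log units; beyond the scatter). These steps show that the ring at this position changes the read-out a good deal, but they give no direction for shifting the amine alone. Since compound 3 holds the lowest number with the 2-aminophenyl, moving the amine is expected to give a modest rise, a 2.0-fold higher number from compound 3 to compound 4 (0.30 log units; within the scatter). Compound 4 is therefore estimated at 5000 nM in this assay, within a range from 1500 nM to 20000 nM.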

Compound 4, concentration for 50% growth inhibition: > 150000 nM
Compound 4 ended at the assay's limit; the forecaster's own chance of this, stated with the estimate: 5%; middle value at least 30-fold (1.47 log units) away from the limit.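

In this assay, the place of the amine on the phenyl ring turns out to matter a great deal: with the same atoms joined differently, 3-aminophenyl in place of 2-aminophenyl gives an at least 60-fold higher number from compound 3 to compound 4 (1.77 log units; beyond the scatter), a change that the earlier swaps of the whole ring could not isolate. An aminophenyl group is therefore not enough on its own, as 3-aminophenyl in place of thiophen-3-yl gives an at least 12-fold higher number from compound 1 to compound 4 (1.09 log units; beyond the scatter), whereas compound 3 goes the other way. The value of compound 4 is a limit of the assay and not a number, and the step to it from compound 2 cannot be read: the limit of > 150000 nM in this assay, at which 1 of the 4 values shown sits.

Going by these compounds, it stays open whether a hydroxyl or a carboxylic acid in place of the amine on the phenyl ring would keep the read-out of compound 3. On these data alone, whether a longer chain carrying the amine would keep it is also open.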